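Carboxypyridinyl in Place of Methoxyphenyl on the Oxazole Core

This account rests on a few compounds, and the source may have more. Where it says the series, first, only, none or still open, it means among the compounds named here.

The study compares three ketones with a shared core and a varied aromatic group. In an assay (Rattus norvegicus) for inhibition of Fatty-acid amide hydrolase 1 (Homo sapiens) (on this read-out lower numbers stand for stronger inhibition and higher numbers for weaker inhibition), compound 1 `N#Cc1ccccc1-c1cnc(C(=O)CCCCCCc2ccccc2)o1` gives 130 nM, compound 2 `O=C(CCCCCCc1ccccc1)c1ncc(-c2ccc(F)cc2)o1` gives 62 nM, and compound 3 `COc1ccc(-c2cnc(C(=O)CCCCCCc3ccccc3)o2)cc1` gives 100 nM. Compound 3 has the second highest number of the three; its gaps to compound 1 and to compound 2 are both within the scatter, so no order among them can be stated. The step of a 2.1-fold lower number from compound 1 to compound 2 (0.32 log units; beyond the scatter) is the only one beyond the scatter, while a 1.3-fold lower number from compound 1 to compound 3 (0.11 log units; within the scatter) and a 1.6-fold higher number from compound 2 to compound 3 (0.21 log units; within the scatter) are not.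

Compound 4 `O=C(CCCCCCc1ccccc1)c1ncc(-c2ncccc2C(=O)O)o1` changes the aromatic group: 3-carboxypyridin-2-yl in place of 4-methoxyphenyl on an aromatic carbon. Within the data shown here, no measured step brings in a ring nitrogen or a hydrogen-bond donor, so the steps above bear on the change only loosely; they show that swapping this aromatic group has moved this assay by modest amounts at most. On that basis compound 4 is expected to give 200 nM, within 60 nM to 800 nM, a step of a 2.0-fold higher number from compound 3 to compound 4 (0.30 log units; within the scatter) that is estimated to be near the scatter, leaning weaker, with wide uncertainty.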

Compound 4, inhibition constant: > 50 nM
Compound 4: a limit, no number; the forecaster's own chance of this, stated with the estimate: 5%; the middle value is on the limit's open side.
By their numbers in this assay, from the lowest: compounds 2, 3 and 1 (each within the scatter of the next, the first and the last beyond it).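

In this assay compound 4 gives > 50 nM, which is a limit and not a number. The steps from compound 1, compound 2 and compound 3 to compound 4 cannot be read. The compounds shown leave open how 3-carboxypyridin-2-yl compares with the other aromatic groups on the shared core.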